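Side chain swap at the assay limit

This account rests on a few compounds, and the source may have more. Where it says the series, first, only, none or still open, it means among the compounds named here.

Measured in an ADME assay on Akata cells (Homo sapiens) for cytotoxicity, with a stated time of 7 days; a higher number here means that more compound is tolerated, a lower number that less compound is tolerated:
Compound 1 `Nc1nc(OCc2ccccc2)c2ncn(/C=C3/CC3(CO)CO)c2n1`: > 20000 nM (a limit)
Compound 2 `CCCOc1nc(N)nc2c1ncn2/C=C1/CC1(CO)CO`: > 20000 nM (a limit)

Compound 2 gives no number in this assay: its > 20000 nM is a limit. Among the compounds with values here, the same is true of the only other compound measured, as the limit of > 20000 nM in this assay, at which 2 of the 2 values shown sit, shows.

The next compound to be measured is compound 3 `CCCCSc1nc(N)nc2c1ncn2/C=C1/CC1(CO)CO`. The change is butylsulfanyl in place of propoxy on an aromatic carbon, with the rest of the structure untouched.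

Within the data shown here, the one measured step that bears on this is a step that the two limits leave unreadable from compound 1 to compound 2. It too exchanges a side chain, but it has no readable size, so it cannot serve as a yardstick for the new change. Among the measured compounds shown here, no measured compound carries butylsulfanyl either.

What remains is the plain observation that compound 2 sits at > 20000 nM, again a limit. On that basis, no step beyond the usual scatter is expected in this assay, and compound 3 may well be reported as a limit too.

The estimated outcome is a number no higher from compound 2 to compound 3 (the limit leaves the size open).

For compound 3 the expected value is 20000 nM, with an estimated range from 7000 nM to 30000 nM.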

Compound 3, half-maximal cytotoxic concentration: > 20000 nM
Compound 3 was reported as a limit (the forecaster's own chance of this, stated with the estimate: 65%); the middle value sits exactly at the limit.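

In this assay compound 3 gives > 20000 nM, which is a limit. Within the data shown here, no step can therefore be read from compound 2 to compound 3 or from compound 1 to compound 3. The compounds shown leave open whether compound 1, compound 2 and compound 3 differ at all in this assay, since none of them gives a number: the limit of > 20000 nM in this assay, at which 3 of the 3 values shown sit.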